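The source may report more compounds than this note shows. Statements on the series, on what has been measured and on what is new or still open speak of the compounds shown alone.

Three analogues sharing one core have been tested in a functional assay on A549 cells (Homo sapiens) for cytotoxicity, read by MTT assay, with a stated time of 48 h; on this read-out higher numbers stand for weaker inhibition and lower numbers for stronger inhibition. Compound 1 `Cc1ccc(S(=O)(=O)/N=C(/CCNC2=CC(=O)c3ccccc3C2=O)Nc2cccc(C(F)(F)F)c2)cc1` gives 78500 nM. Compound 2 `COc1ccc(N/C(CCNC2=CC(=O)c3ccccc3C2=O)=N\S(=O)(=O)c2ccc(C)cc2)cc1OC` gives 20500 nM, and compound 3 `Cc1ccc(S(=O)(=O)/N=C(/CCNC2=CC(=O)c3ccccc3C2=O)NCc2ccccc2)cc1` gives 7410 nM. Among these three numbers compound 2 stands second highest: the step is a 3.8-fold lower number from compound 1 to compound 2 (0.58 log units; beyond the scatter) on one side and a 2.8-fold lower number from compound 2 to compound 3 (0.44 log units; beyond the scatter) on the other, while the widest step among the measured compounds is an 11-fold lower number from compound 1 to compound 3 (1.03 log units; beyond the scatter).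

Compound 4 `Cc1ccc(S(=O)(=O)/N=C(/CCNC2=CC(=O)c3ccccc3C2=O)NC2CCCCC2)cc1` has not yet been measured. Its change from compound 2 is cyclohexyl in place of 3,4-dimethoxyphenyl on an amine nitrogen. Within the data shown here, no measured step exchanges an aromatic ring for a non-aromatic one on this nitrogen, so the guidance is indirect. Among the measured compounds shown here, the closest guide is a 2.8-fold lower number from compound 2 to compound 3 (0.44 log units; beyond the scatter), where the only group that is not an aryl ring on this nitrogen gave the lowest number of the three, and a 3.8-fold lower number from compound 1 to compound 2 (0.58 log units; beyond the scatter) together with an 11-fold lower number from compound 1 to compound 3 (1.03 log units; beyond the scatter) shows that substituents at this position shift the read-out over a moderate range. Since compound 3 gives 7410 nM, compound 4 is expected to show a modest lowering of the number, estimated as a 2.6-fold lower number from compound 2 to compound 4 (0.41 log units; beyond the scatter). Compound 4 is therefore estimated at 8000 nM, with a range from 3000 nM to 25000 nM.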

Compound 4, half-maximal inhibitory concentration: 14700 nM
Compound 4: the middle estimate sits 1.8-fold (0.26 log units) below what was measured; the measured number falls inside the stated range.
By their numbers in this assay, from the lowest: compounds 3, 4 and 2 (each within the scatter of the next, the first and the last beyond it); then compound 1.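

In this assay, among these compounds, cyclohexyl in place of 3,4-dimethoxyphenyl on the amine nitrogen is the first exchange of an aromatic ring for a non-aromatic one at this place, and it stays within the scatter (a 1.4-fold lower number from compound 2 to compound 4 (0.14 log units; within the scatter)). Compound 4 also cannot be separated from the benzyl analogue (a 2.0-fold higher number from compound 3 to compound 4 (0.30 log units; within the scatter)), so it bridges two compounds that are separated from each other, and the cyclohexyl ring does not set a new level at this position. Only the 3-(trifluoromethyl)phenyl analogue stands clearly apart from cyclohexyl (a 5.3-fold lower number from compound 1 to compound 4 (0.73 log units; beyond the scatter)), which shows that an aromatic ring directly on this nitrogen does not by itself bring the highest number, since compound 2 also carries one and stays within the scatter of compound 4.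

No supporting data bear on why these numbers differ. From the compounds shown here alone, it remains open whether a phenethyl group, a cyclopropyl ring, an open butyl chain or a morpholine-bearing chain on this nitrogen would move the number beyond the narrow band that compound 2, compound 3 and compound 4 occupy.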